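A thiazole in place of a pyrimidine on the sulfone

This account rests on a few compounds, and the source may have more. Where it says the series, first, only, none or still open, it means among the compounds named here.

Compound 1 `COc1cccc(S(=O)(=O)c2ccc(NC(=O)C(C)(O)C(F)(F)F)cc2)c1` gives 16000 nM in a functional assay (Cavia porcellus) with sulfonylurea receptors; K-ATP channels (Homo sapiens) as the target; a higher number here means a weaker inhibitor, a lower number a stronger inhibitor.
Compound 2 `CC(O)(C(=O)Nc1ccc(C(O)c2ccccc2)cc1)C(F)(F)F` reaches only a limit of the assay, > 30000 nM.
Compound 3 `CC(O)(C(=O)Nc1ccc(S(=O)(=O)c2cncnc2)cc1)C(F)(F)F` reaches only a limit of the assay, > 30000 nM.

Compound 3 thus stands at the weak end of what has been measured; (the limit of > 30000 nM in this assay, at which 2 of the 3 values shown sit). Going by the values given here, the one step that joins two measured compounds in a single place, an at least 1.8-fold higher number from compound 1 to compound 3 (0.27 log units; that floor lies within the scatter), runs from a number to a limit, so its true size remains open.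

Compound 4 `CC(O)(C(=O)Nc1ccc(S(=O)(=O)c2cncs2)cc1)C(F)(F)F` has not yet been measured. It differs from compound 3 in one place: 1,3-thiazol-5-yl in place of pyrimidin-5-yl on a sulfonyl sulfur. Among the compounds with values here, both groups are aromatic heterocycles on the sulfonyl sulfur, and the only measured step at that position, an at least 1.8-fold higher number from compound 1 to compound 3 (0.27 log units; that floor lies within the scatter), ended at a limit. Within the data shown here, no measured pair shows a change between two heteroaryl groups at this site. The estimated step is therefore a number no higher from compound 3 to compound 4 (the limit leaves the size open), meaning no shift beyond the scatter is expected. Compound 4 is expected to give about 30000 nM, with a range from 10000 nM to 80000 nM, most likely again as a limit only.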

Compound 4, half-maximal inhibitory concentration: 7700 nM
Estimate against measurement, compound 4: 3.9-fold (0.59 log units) above; measured number outside the range, below it.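

Going by these compounds alone, at the sulfonyl sulfur, a change from one aromatic heterocycle to another now moves the number in this assay beyond the scatter, with an at least 3.8-fold lower number from compound 3 to compound 4 (0.59 log units; beyond the scatter) as the step, which the earlier compounds could not show. The 1,3-thiazol-5-yl group also improves on 3-methoxyphenyl on that sulfur, with a 2.1-fold lower number from compound 1 to compound 4 (0.32 log units; beyond the scatter) as the step, and the (1,3-thiazol-5-yl)sulfonyl group improves on hydroxy(phenyl)methyl, with an at least 3.8-fold lower number from compound 2 to compound 4 (0.59 log units; beyond the scatter) as the step. Two of these steps are only floors, and they start from a limit of the assay: (the limit of > 30000 nM in this assay, at which 2 of the 4 values shown sit).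

Going by these compounds, the true size of those two steps stays open, as does whether the gain goes with the sulfur atom of the 1,3-thiazol-5-yl group or with its five-membered ring. An oxazol-5-yl group, with oxygen in place of that sulfur, on the sulfonyl sulfur would separate the two.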